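Phenoxy for acetamido: expected cytotoxicity of compound 3

This account rests on a few compounds, and the source may have more. Where it says the series, first, only, none or still open, it means among the compounds named here.

Compound 2 `CC(=O)Nc1ccc(-n2cc(COc3ccc4c(C)cc(=O)oc4c3)nn2)cc1` is one of two measured compounds. In an ADME assay on Huh-7 cells (Homo sapiens) for cytotoxicity, read by MTT assay, with a stated time of 72 h (on this read-out lower numbers stand for higher toxicity in this test and higher numbers for lower toxicity in this test), compound 2 gives > 100 ug/mL, which is a limit of the assay rather than a number. Compound 1 `Cc1cc(=O)oc2cc(OCc3cn(-c4ccc(Cl)cc4)nn3)ccc12` carries a chloro where compound 2 carries the acetamido. In this assay compound 1 gives > 100 ug/mL, also a limit. The step that the two limits leave unreadable from compound 1 to compound 2 thus has no readable size, since both values sit at the limit of > 100 ug/mL in this assay, at which 2 of the 2 values shown sit.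

Compound 3 `Cc1cc(=O)oc2cc(OCc3cn(-c4ccc(Oc5ccccc5)cc4)nn3)ccc12` carries phenoxy in place of acetamido on an aromatic carbon, a phenoxy in place of acetamido on an aromatic carbon, para to a large group. Among the compounds with values here, the only measured step touching this aromatic carbon is the one from compound 1 to compound 2, and its size is not readable. No step beyond the scatter can therefore be expected in this assay. Compound 3 is estimated at 120 ug/mL, with a range from 50 ug/mL to 300 ug/mL. The expected step that the limit leaves unreadable from compound 2 to compound 3 is accordingly small.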

Compound 3, half-maximal cytotoxic concentration: > 100 ug/mL
Compound 3: a limit, no number (the forecaster's own chance of this, stated with the estimate: 65%); the middle value lies beyond the limit too.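

Within the data shown here, no step among compound 1, compound 2 and compound 3 can be read, since all three values are limits of the assay and not numbers: (the limit of > 100 ug/mL in this assay, at which 3 of the 3 values shown sit). Whether chloro, acetamido or phenoxy on this aromatic carbon makes any difference in this assay stays open, as does the concentration at which any of these compounds turns toxic.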